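From Thiophene to Benzothiophene: Expected Effect on Growth Inhibition

The compounds below may be only part of what the source reports. "The series", "measured", "known", "first", "only" and "open" are said of these compounds alone.

For the measured compounds named here, compound 2 `Cc1ccc(S(=O)(=O)Nc2ccc(-c3ccsc3)c3cccnc23)cc1` holds the lowest of the two numbers measured so far in a functional assay on HT-1080 cells (Homo sapiens) for antiproliferative activity, with a stated time of 6 days (a higher number here means a weaker inhibitor of growth, a lower number a stronger inhibitor of growth), giving 640 nM. Its nearest neighbour, compound 1 `Cc1ccc(S(=O)(=O)Nc2ccc(-c3ccccc3)c3cccnc23)cc1`, gives 1640 nM in this assay, and the change separating them, thiophen-3-yl in place of phenyl on an aromatic carbon, produced a 2.6-fold lower number from compound 1 to compound 2 (0.41 log units; beyond the scatter). Compound 3 `Cc1ccc(S(=O)(=O)Nc2ccc(-c3cc4ccccc4s3)c3cccnc23)cc1` differs from compound 2 by 1-benzothiophen-2-yl in place of thiophen-3-yl on an aromatic carbon. Going by the values given here, only the step from compound 1 to compound 2 bears on this change, and it was modest; the entering group keeps a five-membered aromatic ring with one hetero atom but adds a fused six-membered aromatic ring of carbon only, and no measured pair shows what such a fusion does here. The expected step is a 1.3-fold higher number from compound 2 to compound 3 (0.10 log units; within the scatter), which means no change beyond the scatter is anticipated. The estimate for compound 3 in this assay is 800 nM, with a range from 250 nM to 2500 nM.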

Compound 3, concentration for 50% growth inhibition: 150 nM
Estimate against measurement, compound 3: 5.3-fold (0.73 log units) above, and the stated range ends above it.
By their numbers in this assay, from the lowest: compound 3; then compound 2; then compound 1.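

In this assay, this position on the aromatic carbon para to a large group accepts a fused bicyclic substituent: adding a six-membered aromatic ring of carbon only to the sulfur ring gave a 4.3-fold lower number from compound 2 to compound 3 (0.63 log units; beyond the scatter). Measured against the original phenyl group, 1-benzothiophen-2-yl gave an 11-fold lower number from compound 1 to compound 3 (1.04 log units; beyond the scatter), so among these three compounds the number falls from phenyl to thiophen-3-yl to 1-benzothiophen-2-yl, with no compound going against that order. No measurement bears on why the fused group gives the lower number.

The step from compound 2 to compound 3 also moves the attachment point of the sulfur ring, so a thiophen-2-yl or 1-benzothiophen-3-yl group would be needed to separate that move from the fusion itself. A naphthyl or indol-2-yl group would show whether the sulfur atom matters at this position.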